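A few compounds are considered here, and "the series" means these few. Any claim that something is new, unique, unknown or untested is made for them only; others in the source may bear on it.

Series in a functional assay on MCF7 cells (Homo sapiens) for inhibition, read by MTT assay, with a stated time of 48 h; a higher number here means a weaker inhibitor of growth, a lower number a stronger inhibitor of growth:
Compound 1 `Cn1cc(C2CC(c3ccccc3)=NN2C(=O)c2cccnc2)c2cc(Br)ccc21`: 1520 nM
Compound 2 `COc1ccc2c(c1)c(C1CC(c3ccccc3)=NN1C(=O)c1ccc(OC)nc1)cn2C`: 990 nM
Compound 3 `COc1ccc2c(c1)c(C1CC(c3ccc(F)cc3)=NN1C(=O)c1ccc(OC)nc1)cn2C`: 480 nM

Compound 3 has the lowest number of the three, clear of both others by more than the scatter. Compound 4 `COc1ccc2c(c1)c(C1CC(c3ccc(Cl)cc3)=NN1C(=O)c1ccc(OC)nc1)cn2C` is the next to be read. The change is chloro in place of fluoro on an aromatic carbon, para to a large group. Among the measured compounds shown here, only one measured step bears on it, the modest 2.1-fold lower number from compound 2 to compound 3 (0.31 log units; beyond the scatter), where fluoro replaced hydrogen. For the measured compounds named here, no measured compound carries chloro there, so the direction is uncertain. A small further drop in this assay is expected, at most comparable to that step. The expected change is a 1.1-fold lower number from compound 3 to compound 4 (0.06 log units; within the scatter). Compound 4 is estimated at 420 nM, with an expected range of 190 nM to 900 nM.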

Compound 4, concentration for 50% growth inhibition: 3710 nM
Estimate against measurement, compound 4: 8.8-fold (0.95 log units) below; measured number above the stated range.
By their numbers in this assay, from the lowest: compound 3; then compounds 2 and 1 (each within the scatter of the next); then compound 4.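

In this assay the change from 4-fluorophenyl to 4-chlorophenyl gives a 7.7-fold higher number from compound 3 to compound 4 (0.89 log units; beyond the scatter) and so shows that this position does not treat the two halogens alike. Against hydrogen the two halogens part in direction: fluoro gives a 2.1-fold lower number from compound 2 to compound 3 (0.31 log units; beyond the scatter) while chloro gives a 3.7-fold higher number from compound 2 to compound 4 (0.57 log units; beyond the scatter) at the same place. A single halogen step therefore cannot be carried over to another halogen here.

As far as these compounds go, whether bromo, methyl or methoxy at this place follows fluoro or chloro stays open. No available evidence bears on this result.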